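The source may report more compounds than this note shows. Statements on the series, on what has been measured and on what is new or still open speak of the compounds shown alone.

Compound 3 `COc1ccc(OC(=O)c2cn(-c3ccccc3)nc2-c2ccncc2)cc1` stands at the edge of what a functional assay on HeLa cells (Homo sapiens) for cytotoxicity, read by MTT assay, with a stated time of 48 h (on this read-out higher numbers stand for weaker inhibition and lower numbers for stronger inhibition), can report: in this assay compound 3 gives > 100000 nM, which is a limit rather than a number. Compound 1 `COc1ccc(OC(=O)c2cn(-c3ccccc3)nc2-c2cccnc2)cc1` shares the core and carries pyridin-3-yl where compound 3 carries pyridin-4-yl. In this assay compound 1 likewise gives > 100000 nM, again a limit. The step that the two limits leave unreadable from compound 1 to compound 3 therefore stays unreadable. Compound 2 `O=C(c1cn(-c2ccccc2)nc1-c1ccncc1)N1CCC(Cc2ccccc2)CC1` has an amide instead of the ester and differs from compound 3 in more than one place; in this assay compound 2 gives 32800 nM. Compound 4 `CC(C)(C)c1ccc(OC(=O)c2cn(-c3ccccc3)nc2-c2ccncc2)cc1` carries the change (tert-butyl in place of methoxy on an aromatic carbon). For the measured compounds named here, no measured step touches this group, and the limit of > 100000 nM in this assay, at which 2 of the 3 values shown sit, leaves both the size and the direction of any effect unread. The estimate for compound 4 in this assay is 100000 nM, within 30000 nM to 300000 nM. The expected step of a number no higher from compound 3 to compound 4 (the limit leaves the size open) is none beyond the scatter, and compound 4 is expected most likely to return only a limit again.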

Compound 4, half-maximal inhibitory concentration: 35400 nM
For compound 4 the middle estimate is 2.8-fold (0.45 log units) above the measured one; the measured number falls inside the stated range.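

In this assay, for the compounds shown here, the change from methoxy to tert-butyl, on an aromatic carbon para to a large group, gives the first readable step at this position: an at least 2.8-fold lower number from compound 3 to compound 4 (0.45 log units; beyond the scatter). Among the ester compounds shown, this is the first change that moves the read-out from a limit to a number, which shows that this position can alter the result. The step gives only a bound on the size of the effect, because its starting value is a limit: the limit of > 100000 nM in this assay, at which 2 of the 4 values shown sit.

Only methoxy and tert-butyl are shown at this position, and it stays open whether an amine, a trifluoromethyl group or a longer alkyl chain there would also give a number or would return a limit. Going by these compounds, it also stays open whether tert-butyl would have the same effect with pyridin-3-yl in place of pyridin-4-yl.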